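Removing the Isopropoxy Group from Compound 2

A few compounds are considered here, and "the series" means these few. Any claim that something is new, unique, unknown or untested is made for them only; others in the source may bear on it.

Compound 2 `CC(C)Oc1cc(-c2cncc(-c3cnn(C)c3)c2)ccc1C(N)=O` holds the second highest of three numbers in an assay on cells for inhibition of MAP kinase-interacting serine/threonine-protein kinase 1 (Homo sapiens), read by mobility shift assay, with stated times of 10 min and 60 min, in the presence of a further agent that is not named here (a lower number here means a stronger inhibitor, a higher number a weaker inhibitor), where compound 2 gives 400 nM. Its nearest neighbour is compound 3 `CC(C)Oc1cc(-c2cncc(-c3c[nH]nc3C3CC3)c2)ccc1C(N)=O`, which in this assay gives 130 nM; the step of a 3.1-fold lower number from compound 2 to compound 3 (0.49 log units; beyond the scatter) exchanges one pyrazole substituent for another. Furthest away is compound 1 `COc1cncc(-c2ccc(C(N)=O)cc2)c1`, which in this assay gives 3000 nM; compound 1 differs from compound 2 in more than one place, so the two values show only that compound 1, which lacks both the isopropoxy and the pyrazole, gives the higher number.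

Compound 4 `Cn1cc(-c2cncc(-c3ccc(C(N)=O)cc3)c2)cn1` arises from compound 2 by hydrogen in place of isopropoxy on an aromatic carbon. Among the compounds with values here, none of the measured steps touches this group: the only single-place step, a 3.1-fold lower number from compound 2 to compound 3 (0.49 log units; beyond the scatter), concerns the pyrazole and says nothing about the isopropoxy. The higher number of compound 1 is the only hint that the series loses potency when this part is stripped back, but that comparison carries a second difference as well. The step of a 3.8-fold higher number from compound 2 to compound 4 (0.57 log units; beyond the scatter) is therefore expected to run towards a higher number, of moderate size, with wide uncertainty. Compound 4 is expected to give about 1500 nM in this assay, within a range from 500 nM to 5000 nM.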

Compound 4, half-maximal inhibitory concentration: 800 nM
Estimate against measurement, compound 4: 1.9-fold (0.27 log units) above, and the stated range covers the measured number.
By their numbers in this assay, from the lowest: compound 3; then compounds 2 and 4 (each within the scatter of the next); then compound 1.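

In this assay, hydrogen in place of isopropoxy, on an aromatic carbon ortho to a carbamoyl group, gives a 2.0-fold higher number from compound 2 to compound 4 (0.30 log units; within the scatter), so this single-place comparison gives no sign that the isopropoxy group is needed for the number seen with compound 2. Within the data shown here, with hydrogen at that position in both compounds, 1-methyl-1H-pyrazol-4-yl in place of methoxy gives a 3.8-fold lower number from compound 1 to compound 4 (0.57 log units; beyond the scatter), which is the first reading of that exchange on its own and the only one of the two new steps that lies beyond the scatter. The data shown offer no measurement that would explain the size of either step.

The compounds shown leave open whether hydrogen in place of isopropoxy would read the same way alongside the 3-cyclopropyl-1H-pyrazol-4-yl group of compound 3, which has the lowest number of the four. They also leave open how an amine, a hydroxyl or a longer alkoxy chain ortho to the carbamoyl group would read in this assay, as only isopropoxy and hydrogen appear at that position here.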